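This account rests on a few compounds, and the source may have more. Where it says the series, first, only, none or still open, it means among the compounds named here.

Working notes on the series. In a functional assay on M21 cells (Homo sapiens) for antiproliferative activity, read by sulforhodamine B assay, with a stated time of 48 h (on this read-out lower numbers stand for stronger inhibition and higher numbers for weaker inhibition), compound 1 `CCCCCc1ccc(NS(=O)(=O)c2ccc(N3CCNC3=O)cc2)cc1` gives 870 nM. For compound 2 `O=C1NCCN1c1ccc(S(=O)(=O)Nc2ccc(C3CCCCC3)cc2)cc1` this assay reports only a limit, > 1000 nM. For compound 3 `CCCCCCOc1ccc(NS(=O)(=O)c2ccc(N3CCNC3=O)cc2)cc1` this assay likewise reports only a limit, > 1000 nM, so compound 3 stands with no number of its own among the values shown. The next step goes to compound 4 `O=C1NCCN1c1ccc(S(=O)(=O)Nc2ccc(Cl)cc2)cc1`: chloro in place of hexyloxy on an aromatic carbon. The measured steps that touch compound 3 are an at least 1.1-fold higher number from compound 1 to compound 3 (0.06 log units; that floor lies within the scatter) and a step that the two limits leave unreadable from compound 2 to compound 3; both rest on limits because of the limit of > 1000 nM in this assay, at which 2 of the 3 values shown sit. Going by the values given here, no measured step therefore fixes a direction or a size for the present change beyond the scatter. The number of compound 4 is expected at 2000 nM, within 600 nM to 8000 nM, and may again be a limit. The corresponding step is estimated as a step that the limit leaves unreadable from compound 3 to compound 4.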

Compound 4, half-maximal inhibitory concentration: 90 nM
The estimate for compound 4 lay 22-fold (1.35 log units) above the measured number, outside the stated range (below it).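

In this assay, going by these compounds alone, chloro on this aromatic carbon gives the first steps that lie beyond the scatter: a 9.7-fold lower number from compound 1 to compound 4 (0.99 log units; beyond the scatter) with pentyl replaced, an at least 11-fold lower number from compound 2 to compound 4 (1.04 log units; beyond the scatter) with cyclohexyl replaced and an at least 11-fold lower number from compound 3 to compound 4 (1.04 log units; beyond the scatter) with hexyloxy replaced. The last two steps are floors that rest on a limit, not on a number: the limit of > 1000 nM in this assay, at which 2 of the 4 values shown sit. Chloro alone separates from the other three groups.

A methyl, methoxy or fluoro group at this place would show whether a short group is enough or chloro itself is needed. The order among cyclohexyl, hexyloxy and pentyl remains unreadable.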